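From Cyclohexyl to Benzyl on the Amide Nitrogen

The source may report more compounds than this note shows. Statements on the series, on what has been measured and on what is new or still open speak of the compounds shown alone.

Compound 1, `O=C(O)CCc1cccc2c1B(O)OC2`, compound 2, `CCNC(=O)CCc1cccc2c1B(O)OC2`, and compound 3, `O=C(CCc1cccc2c1B(O)OC2)NC1CCCCC1`, share one core and differ only in the group attached to the carbonyl carbon or to the amide-type nitrogen. In an ADME assay on WI-38 cells (Homo sapiens) for cytotoxicity, read by MTT assay, with a stated time of 72 h (a lower number here means a stronger inhibitor, a higher number a weaker inhibitor), compound 1 reaches only a limit of the assay rather than a number, > 100000 nM. In this assay compound 2 also reaches only the limit, > 100000 nM. In this assay compound 3 likewise reaches only the limit, > 100000 nM. The three steps among them, a step that the two limits leave unreadable from compound 1 to compound 2, a step that the two limits leave unreadable from compound 1 to compound 3 and a step that the two limits leave unreadable from compound 2 to compound 3, cannot be read in size because of the limit of > 100000 nM in this assay, at which 3 of the 3 values shown sit.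

Compound 3 therefore stands at the limit, with no number behind it. Compound 4, `O=C(CCc1cccc2c1B(O)OC2)NCc1ccccc1`, differs from compound 3 by benzyl in place of cyclohexyl on an amide-type nitrogen. The measured steps all concern changes at the same carbonyl carbon or amide-type nitrogen, yet none gave a readable size, so no direction beyond the scatter can be drawn from them for this assay. Compound 4 is expected to sit at the limit as well, 100000 nM, with a range from 30000 nM to 300000 nM. The change is estimated to amount to a number no higher from compound 3 to compound 4 (the limit leaves the size open).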

Compound 4, half-maximal inhibitory concentration: > 100000 nM
Compound 4: only a limit was reported (the forecaster's own chance of this, stated with the estimate: 85%); the middle value sits exactly at the limit.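

In this assay compound 4 gives > 100000 nM, which is a limit and not a number. The steps from compound 2 and compound 3 to compound 4 therefore cannot be read in size, because all the values share one limit: the limit of > 100000 nM in this assay, at which 4 of the 4 values shown sit.

The compounds shown leave open how they rank against one another and what concentration, if any, would harm these cells.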